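The source may report more compounds than this note shows. Statements on the series, on what has been measured and on what is new or still open speak of the compounds shown alone.

Compound 3 `Oc1ccc(C[C@H]2COC[C@@H]2Cc2ccc(Cl)c(Cl)c2)cc1` gives 31000 nM in a functional assay on HL-60 cells (Homo sapiens) for cytotoxicity, read by WST assay, with a stated time of 48 h; a lower number here means that less compound is needed, a higher number that more compound is needed for the effect. It stands level with compound 2 `Oc1cccc(C[C@H]2COC[C@@H]2Cc2ccc(Cl)c(Cl)c2)c1`, which gives 31000 nM, and compound 1 `Oc1ccccc1C[C@H]1COC[C@@H]1Cc1ccc(Cl)c(Cl)c1`, which gives 34000 nM, lies within the scatter of both. The three steps among them are all small: a 1.1-fold lower number from compound 1 to compound 2 (0.04 log units; within the scatter), a 1.1-fold lower number from compound 1 to compound 3 (0.04 log units; within the scatter) and no change at the digits printed from compound 2 to compound 3 (within the scatter). Compound 4 `Cc1ccc(C[C@H]2COC[C@@H]2Cc2ccc(Cl)c(Cl)c2)cc1` is the next compound, and it differs from compound 3 by methyl in place of hydroxy on an aromatic carbon. The measured steps move the hydroxy around the ring but never replace it, so none of them bears directly on this change; they show only that where the hydroxy sits makes no difference beyond the scatter. With nothing measured on a hydroxy-to-methyl exchange, the estimate for compound 4 rests on the flat picture across compounds 1, 2 and 3, and the expected step is no change at the digits printed from compound 3 to compound 4 (within the scatter), that is, no change beyond the scatter. Compound 4 is therefore estimated at 31000 nM in this assay, within a range of 12000 nM to 80000 nM.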

Compound 4, half-maximal effective concentration: 21000 nM
Estimate against measurement, compound 4: 1.5-fold (0.17 log units) above, within the range that was stated.
By their numbers in this assay, from the lowest: compounds 4, 2, 3 and 1 (each within the scatter of the next).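

In this assay, methyl on this aromatic carbon, para to a large group, reads as a 1.5-fold lower number from compound 3 to compound 4 (0.17 log units; within the scatter) and so cannot be told apart from hydroxy, even though the hydrogen-bond donor and acceptor counted for hydroxy are absent from methyl. Set against the other two hydroxyphenyl compounds, 4-methylphenyl gives a 1.5-fold lower number from compound 2 to compound 4 (0.17 log units; within the scatter) and a 1.6-fold lower number from compound 1 to compound 4 (0.21 log units; within the scatter), which extends the flat picture in these four compounds from moving the hydroxy around the ring to removing it altogether. Nothing at hand accounts for how little this exchange shows in the number.

From the compounds shown here alone, it remains open whether an amine, a carboxylic acid or a longer chain at this position would move the number beyond the scatter. Going by these compounds, it is also open whether methyl would read the same where compound 1 and compound 2 carry their hydroxy.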